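A few compounds are considered here, and "the series" means these few. Any claim that something is new, unique, unknown or untested is made for them only; others in the source may bear on it.

Compound 3 `COc1ncccc1C(=O)NCCC1CCN(S(=O)(=O)NC(=O)NC2CCCCC2)CC1` stands highest of the three compounds measured in a functional assay on the whole organism (blood) with Rattus norvegicus as the target, with stated times of 24 h and 1 h, at a dose of 15 mg/kg by the intraperitoneal route (a lower number here means a weaker effect, a higher number a stronger effect of the compound at the dose given), where compound 3 gives 35%. Its nearest neighbour is compound 2 `CSc1ccc(C(F)(F)F)cc1C(=O)NCCC1CCN(S(=O)(=O)NC(=O)NC2CCCCC2)CC1`, which in this assay gives 24%; the furthest is compound 1 `Cn1cc(C(=O)NCCC2CCN(S(=O)(=O)NC(=O)NC3CCCCC3)CC2)c(=O)n(C)c1=O`, which gives 15%. The steps read a number 11 percentage points higher from compound 2 to compound 3 (beyond the scatter) and a number 20 percentage points higher from compound 1 to compound 3 (beyond the scatter), while a number 9 percentage points higher from compound 1 to compound 2 (within the scatter). Compound 4 `O=C(NC1CCCCC1)NS(=O)(=O)N1CCC(CCNC(=O)c2nsc3ccccc23)CC1` differs from compound 3 at the same place as those exchanges: a group of 9 heavy atoms (7 carbon, 1 nitrogen, 1 sulfur; one five-membered aromatic ring with 2 hetero atoms, one six-membered aromatic ring of carbon only) in place of a group of 8 heavy atoms (6 carbon, 1 nitrogen, 1 oxygen; one six-membered aromatic ring with 1 hetero atom), on a carbonyl carbon. All three measured steps bear on it, since each swapped the aromatic group on the carbonyl carbon, and none moved the activity by more than a modest amount. A step of similar size is therefore expected in this assay, in either direction, and the estimated step is a number 5 percentage points lower from compound 3 to compound 4 (within the scatter). Compound 4 is expected to give 30%, between 12% and 48%.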

Compound 4, a percentage reported as activity, at one dose (the size of the read-out at that dose, not a potency): 17%
Compound 4: middle estimate off by 13 percentage points, on the high side; the measured number falls inside the stated range.
By their numbers in this assay, from the lowest: compounds 1, 4 and 2 (each within the scatter of the next); then compound 3.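

In this assay, the step of a number 18 percentage points lower from compound 3 to compound 4 (beyond the scatter) shows that a two-ring group on this carbonyl carbon does not keep the activity seen with 2-methoxypyridin-3-yl. The steps of a number 7 percentage points lower from compound 2 to compound 4 (within the scatter) and a number 2 percentage points higher from compound 1 to compound 4 (within the scatter) leave the new group indistinguishable from the two earlier groups, so among these four compounds only the 2-methoxypyridin-3-yl group stands apart. No measurement at hand explains this difference. As far as these compounds go, it remains open whether a 2-methoxyphenyl group or a pyridin-3-yl group without the methoxy would hold the activity of compound 3.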